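Anilide ring substitution in a hydrazone series

The source may report more compounds than this note shows. Statements on the series, on what has been measured and on what is new or still open speak of the compounds shown alone.

The shared core of compound 1 `Cc1c(O)c(=O)ccn1CC(=O)N/N=C1\C(=O)N(CC(=O)Nc2ccccc2)c2ccccc21` carries a phenyl on an amide-type nitrogen; in a functional assay on MCF7 cells (Homo sapiens) for cytotoxicity, read by MTT assay, with a stated time of 48 h (a higher number here means that more compound is needed for the effect, a lower number that less compound is needed), compound 1 gives 48400 nM. Compound 2 `CC(=O)Nc1ccc(NC(=O)CN2C(=O)/C(=N\NC(=O)Cn3ccc(=O)c(O)c3C)c3ccccc32)cc1` differs only by an acetamido on that ring, and in this assay compound 2 gives 51900 nM. Among the compounds with values here, the step of a 1.1-fold higher number from compound 1 to compound 2 (0.03 log units; within the scatter) is the only measured change at this position, and it leaves compound 1 and compound 2 within the scatter of each other.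

Compound 3 `Cc1c(O)c(=O)ccn1CC(=O)N/N=C1\C(=O)N(CC(=O)Nc2ccc(Cl)cc2Cl)c2ccccc21` is the next variation on the same ring: 2,4-dichlorophenyl in place of phenyl on an amide-type nitrogen. Within the data shown here, the one step that bears on it, a 1.1-fold higher number from compound 1 to compound 2 (0.03 log units; within the scatter), showed that a substituent on this ring did not move the number beyond the scatter, so the expected step of a 1.2-fold lower number from compound 1 to compound 3 (0.08 log units; within the scatter) is likewise small, with no direction claimed. Compound 3 is therefore expected to give about 40000 nM in this assay, within a range of 14000 nM to 115000 nM.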

Compound 3, half-maximal effective concentration: 43200 nM
Compound 3: middle estimate off by 1.1-fold (0.03 log units), on the low side; measured number inside the range.
By their numbers in this assay, from the lowest: compounds 3, 1 and 2 (each within the scatter of the next).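

Notes on the ring on the amide-type nitrogen: in this assay the 2,4-dichlorophenyl group, the first halogen-bearing ring in the set, gives a 1.1-fold lower number from compound 1 to compound 3 (0.05 log units; within the scatter) against the unsubstituted phenyl. Set against the 4-acetamidophenyl group, the same ring gives a 1.2-fold lower number from compound 2 to compound 3 (0.08 log units; within the scatter) and so also stays inside the scatter. The phenyl, 4-acetamidophenyl and 2,4-dichlorophenyl forms therefore cannot be told apart in this assay, although the two substituted rings carry quite different groups. No measurement bearing on the reason for this flat reading is available.

Still open, as far as these compounds go, is whether a ring carrying an amine or a carboxylic acid would separate from these three compounds. Also open, from the compounds shown here alone, is whether a longer alkyl chain in place of the ring would do so.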